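A few compounds are considered here, and "the series" means these few. Any claim that something is new, unique, unknown or untested is made for them only; others in the source may bear on it.

Of the compounds shown here, three built on one shared core have been measured in an in vitro functional assay on HEK285-7 cells for antagonist activity at prostaglandin D2 receptor 2 (Homo sapiens), read by BRET and beta-arrestin recruitment; a lower number here means a stronger inhibitor, a higher number a weaker inhibitor. Compound 1 `O=C(O)Cc1sc(C(c2ccc(F)cc2)c2ccc(F)cc2)nc1-c1ccnc(N2CCC2)c1` sits at the limit of the assay, > 100000 nM, which is a limit rather than a number (the limit of > 100000 nM in this assay, at which 1 of the 3 values shown sits). Compound 2 `O=C(O)Cc1sc(C(c2ccc(F)cc2)c2ccc(F)cc2)nc1-c1ccccc1` gives 240 nM in this assay, and compound 3 `O=C(O)Cc1sc(C(c2ccc(F)cc2)c2ccc(F)cc2)nc1-c1ccoc1` gives 130 nM. Compound 3 thus holds the lowest of the two numbers, though the step of a 1.8-fold lower number from compound 2 to compound 3 (0.27 log units; within the scatter) lies within the scatter. The steps of an at least 410-fold lower number from compound 1 to compound 2 (2.61 log units; beyond the scatter) and an at least 760-fold lower number from compound 1 to compound 3 (2.88 log units; beyond the scatter) show how far the 2-(azetidin-1-yl)pyridin-4-yl compound stands from the other two.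

Compound 4 `O=C(O)Cc1sc(C(c2ccc(F)cc2)c2ccc(F)cc2)nc1-c1ccncc1` has not yet been measured. It differs from compound 3 in one place: pyridin-4-yl in place of furan-3-yl on an aromatic carbon. The measured step that bears most closely on this is a 1.8-fold lower number from compound 2 to compound 3 (0.27 log units; within the scatter), in which one aromatic ring at this position replaced another and the number stayed within the scatter. Pyridin-4-yl carries the same six-membered ring as phenyl, yet it is also the ring found within the group of compound 1, whose value is a limit. A step of a 3.8-fold higher number from compound 3 to compound 4 (0.59 log units; beyond the scatter) is therefore expected, toward a somewhat higher number. Compound 4 is estimated to give 500 nM in this assay, with a range from 80 nM to 4000 nM.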

Compound 4, half-maximal inhibitory concentration: 40 nM
Estimate against measurement, compound 4: 13-fold (1.10 log units) above; measured number below the stated range.
By their numbers in this assay, from the lowest: compound 4; then compounds 3 and 2 (each within the scatter of the next). At a limit, above all of these: compound 1.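

With pyridin-4-yl on the aromatic carbon next to the ring nitrogen, this assay shows that this position does separate one aromatic ring from another: a 3.3-fold lower number from compound 3 to compound 4 (0.51 log units; beyond the scatter) and a 6.0-fold lower number from compound 2 to compound 4 (0.78 log units; beyond the scatter), whereas the exchange of phenyl for furan-3-yl had stayed within the scatter. The comparison with the substituted ring, an at least 2500-fold lower number from compound 1 to compound 4 (3.39 log units; beyond the scatter), shows that a pyridine ring at this position is compatible with a low number, so the collapse seen in compound 1 goes with the added azetidin-1-yl group and not with the pyridine ring itself. The size of that step is only a lower bound, since the entry for compound 1 is a limit and not a number: the limit of > 100000 nM in this assay, at which 1 of the 4 values shown sits.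

The compounds shown leave open whether the lower number depends on where the nitrogen stands, which pyridin-3-yl or a pyrimidine ring at this position would test. They also leave open whether any group can be carried on the pyridine ring at all, or whether a smaller one such as methyl, methoxy or an open-chain dimethylamino group would keep the number of compound 4.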